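This account rests on a few compounds, and the source may have more. Where it says the series, first, only, none or still open, it means among the compounds named here.

Measured so far:
Compound 1 `O=C(N[C@@H](CO)C(=O)NO)c1ccc(C#Cc2ccccc2)cc1` gives 28000 nM in a physicochemical assay for solubility; a lower number here means a less soluble compound, a higher number a more soluble compound.
Compound 2 `NC(=O)C[C@H](NC(=O)c1ccc(C#Cc2ccccc2)cc1)C(=O)NO` gives 61000 nM in this assay.

Among the compounds with values here, compound 1 stands at the lowest of the two numbers; the only neighbour is compound 2, reached by the step of a 2.2-fold higher number from compound 1 to compound 2 (0.34 log units; beyond the scatter). Compound 3 `O=C(NC1(C(=O)NO)CCC1)c1ccc(C#Cc2ccccc2)cc1`, not yet measured, differs from compound 1 by a group of 8 heavy atoms (5 carbon, 1 nitrogen, 2 oxygen; one four-membered non-aromatic ring of carbon only) in place of a group of 7 heavy atoms (3 carbon, 1 nitrogen, 3 oxygen; no ring), on an amide-type nitrogen. Within the data shown here, the one measured step that touches the same part of the shared core, from compound 1 to compound 2, was modest but beyond the scatter, and it came from a change that kept the open chain and added a carbamoyl. The change to compound 3 is of another kind: the chain closes into a four-membered ring, and the count of hydrogen-bond donors and acceptors falls from three to two. Among the measured compounds shown here, no measured pair shows a step of this kind, so the measured data give direction only loosely. The expectation is therefore a step of a 2.3-fold lower number from compound 1 to compound 3 (0.37 log units; beyond the scatter) in this assay, towards a lower number. Compound 3 is estimated at 12000 nM, with a likely range from 4000 nM to 35000 nM.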

Compound 3, solubility: 5000 nM
Compound 3: the middle estimate sits 2.4-fold (0.38 log units) above what was measured, within the range that was stated.
By their numbers in this assay, from the lowest: compound 3; then compound 1; then compound 2.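

The step at this place on the amide-type nitrogen in this assay is a 5.6-fold lower number from compound 1 to compound 3 (0.75 log units; beyond the scatter) and it runs the opposite way to a 2.2-fold higher number from compound 1 to compound 2 (0.34 log units; beyond the scatter) so the three compounds show that the number at this part of the molecule can move either way. The change to the 1-(hydroxycarbamoyl)cyclobutyl group is a bundle of differences, as it brings a four-membered ring of carbon only, removes the defined stereocentre and lowers the counts of hydrogen-bond donors and acceptors, and this single pair cannot separate them. No accompanying measurement bears on why the number moved as it did.

Still open, as far as these compounds go, is which of these differences goes with the lower number, and an open chain carrying two methyl groups in place of the cyclobutyl ring, or a cyclopentyl ring, would help to tell the ring from the rest of the change. Also open, from the compounds shown here alone, is whether an amine or a carboxylic acid on the cyclobutyl ring would move the number back towards that of compound 1, or whether the ring sets the number regardless.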